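Swapping a Methyl for a Fluoro on the Shared Core

The source may hold more compounds than are shown below. What is called first, only, known or untested is meant among the compounds shown, and "the series" means these compounds.

Of the compounds shown here, two have been tested in an assay on LX2 cells for inhibition of COL1A1 promoter (Homo sapiens), read by a luciferase reporter, with a stated time of 24 h, tested at 20 uM; on this read-out higher numbers stand for a stronger effect at the one concentration tested and lower numbers for a weaker effect. Compound 1, `CN(C)c1ccc2c(=O)c(C(=O)Nc3cc(F)cc(F)c3)cn(-c3ccc(OCCCCCCC[n+]4ccccc4)cc3F)c2n1`, reaches 15.4% in this assay. Compound 2, `Cc1cc(OCCCCCCC[N+]2(C)CCN(C)CC2)ccc1-n1cc(C(=O)Nc2cc(F)cc(F)c2)c(=O)c2ccc(N(C)C)nc21`, is reported only as "not active" (no number reported) in this assay, so no number places it on the scale. The next compound, compound 3, `CN1CC[N+](C)(CCCCCCCOc2ccc(-n3cc(C(=O)Nc4cc(F)cc(F)c4)c(=O)c4ccc(N(C)C)nc43)c(F)c2)CC1`, differs from compound 2 by one change: fluoro in place of methyl on an aromatic carbon. Going by the values given here, with no measured pair of this kind, any step in this assay is expected to stay within the scatter. Compound 3 is therefore expected to give 10%, within 0% to 25%, in this assay.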

Compound 3, a percentage reported as inhibition, at one concentration (the size of the read-out at that concentration, not a potency): "not active" (no number reported)
Compound 3 has no reported number here, so the estimate cannot be set against anything.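

Compound 2 and compound 3 both carry no number in this assay, so no step can be read between them. Nothing available bears on this result. On these data alone, the effect of fluoro in place of methyl therefore remains open.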